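The compounds below may be only part of what the source reports. "The series", "measured", "known", "first", "only" and "open" are said of these compounds alone.

Of the compounds shown here, three built on one shared core have been measured so far in an assay on NK92 cells for inhibition of interleukin-15 (Homo sapiens), read by AlphaScreen, with stated times of 30 min and 1 h; on this read-out lower numbers stand for stronger inhibition and higher numbers for weaker inhibition. Compound 1 `Cn1nc(Cc2nnc(SCC(=O)Nc3ccc(Cl)cc3Cl)n2CCCO)c2ccccc2c1=O` reaches only (the limit of > 30000 nM in this assay, at which 1 of the 3 values shown sits), so for compound 1 the reading > 30000 nM is a limit of the assay and not a number. Compound 2 `Cn1c(Cc2nn(CCC3OCCO3)c(=O)c3ccccc23)nnc1SCC(=O)Nc1ccc(Cl)cc1Cl` gives 30000 nM, and compound 3 `Cn1c(Cc2nn(CCC=O)c(=O)c3ccccc23)nnc1SCC(=O)Nc1ccc(Cl)cc1Cl` gives 20000 nM, so both sit close to that same edge of the assay. Compound 4 `Cn1c(Cc2nn(CCC(=O)O)c(=O)c3ccccc23)nnc1SCC(=O)Nc1ccc(Cl)cc1Cl` is not yet measured; it differs from compound 3 by hydroxy in place of hydrogen on a carbonyl carbon. Among the measured compounds shown here, only one measured step bears on this change: a 1.5-fold lower number from compound 2 to compound 3 (0.18 log units; within the scatter) swapped the end of the same chain two bonds from the aromatic nitrogen without moving the number beyond the scatter, and on that basis the step from compound 3 to compound 4 is expected to be a 1.3-fold higher number from compound 3 to compound 4 (0.10 log units; within the scatter), no movement beyond the scatter in either direction. Compound 4 is therefore estimated at 25000 nM, with a likely range from 10000 nM to 60000 nM.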

Compound 4, half-maximal inhibitory concentration: > 30000 nM
Compound 4 was reported as a limit; the forecaster's own chance of this, stated with the estimate: 40%; middle value at least 1.2-fold (0.07 log units) from the limit.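

The reading for compound 4 is a limit of the assay and not a number, and it places compound 4 with compound 1 at the edge of what can be read: the limit of > 30000 nM in this assay, at which 2 of the 4 values shown sit. From the compounds shown here alone, changing formyl to carboxy at the end of the chain gives an at least 1.5-fold higher number from compound 3 to compound 4 (0.17 log units; that floor lies within the scatter) and so brings no gain, though how far the number rises stays unknown. Changing 1,3-dioxolan-2-yl to carboxy at the end of the chain gives a number no lower from compound 2 to compound 4 (the limit leaves the size open), and none of the three chain ends moves the reading clearly away from that edge.

The compounds shown leave open whether an amine or an amide at the end of this chain, or a longer chain, would give a clearly lower number. They also leave open the true number for compound 4.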